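This account rests on a few compounds, and the source may have more. Where it says the series, first, only, none or still open, it means among the compounds named here.

Working notes on the series. Compound 1 `C=CCCC(=O)N[C@H]1[C@@H](OCCCCCCCCCCCCCCCC)O[C@H](CO)[C@@H](O)[C@@H]1O` and compound 3 `C=CCCC(=O)N[C@H]1[C@@H](OCCCCCCCCCCCCCCCC)O[C@H](CO)[C@@H](O)[C@@H]1OS(=O)(=O)O` share one core; compound 2 `CCCCCCCC/C=C\CCCCCCCCO[C@H]1O[C@H](CO)[C@@H](O)[C@H](O)[C@H]1NC(C)=O` and compound 4 `CCCCCCCC/C=C\CCCCCCCCO[C@H]1O[C@H](COS(=O)(=O)O)[C@@H](O)[C@H](O)[C@H]1NC(C)=O` share another. The difference between the two cores is not broken down here. In a functional assay on C6 cells (Rattus norvegicus), read by thymidine incorporation (on this read-out higher numbers stand for weaker inhibition and lower numbers for stronger inhibition), compound 1 gives only a limit, > 50 uM (the limit of > 50 uM in this assay, at which 1 of the 3 values shown sits). In this assay compound 3 gives 22.6 uM. In this assay compound 2 gives 1.3 uM. The change sulfo in place of hydrogen on an oxygen on a saturated carbon made an at least 2.2-fold lower number from compound 1 to compound 3 (0.34 log units; beyond the scatter). Compound 4 carries the same kind of change, (sulfo in place of hydrogen on an oxygen on a saturated carbon); here the oxygen sits on a saturated carbon whose other neighbour is a saturated chain carbon, rather than a saturated ring carbon as in compound 3. Because an at least 2.2-fold lower number from compound 1 to compound 3 (0.34 log units; beyond the scatter) ran to a lower number, a step of comparable size is expected, a 2.2-fold lower number from compound 2 to compound 4 (0.34 log units; beyond the scatter). Compound 4 is accordingly estimated at 0.6 uM, within 0.2 uM to 2.5 uM.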

Compound 4, concentration for 50% inhibition: 13 uM
Compound 4: middle estimate off by 22-fold (1.34 log units), on the low side; the measured number lies above the stated range.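

In this assay the sulfo change does not carry from one core to the other, and its direction reverses: the same change on two cores in this assay, an at least 2.2-fold lower number (0.34 log units; beyond the scatter) from compound 1 to compound 3 and a 10-fold higher number (1.00 log units; beyond the scatter) from compound 2 to compound 4, at least 22-fold (1.34 log units) apart, beyond the scatter of two such steps

On the second core the change gives a 10-fold higher number from compound 2 to compound 4 (1.00 log units; beyond the scatter). Two pairs do not show whether the core or the site of the sulfo group sets the direction, since the oxygen sits on a saturated carbon whose other neighbour is a saturated ring carbon in compound 3 and a saturated chain carbon in compound 4.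

Open, on these data alone, is whether the direction on each core follows the site of the sulfo group. Also open, as far as these compounds go, is whether a carboxylic acid or a phosphate group in the same place would follow either step.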